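The source may report more compounds than this note shows. Statements on the series, on what has been measured and on what is new or still open speak of the compounds shown alone.

Measured so far in an ADME assay on the whole organism (Mus musculus, strain CD-1) for pharmacokinetics; on this read-out higher numbers stand for fast clearance and lower numbers for slow clearance:
Compound 1 `CCOc1cc([C@](O)(CCN(C)C)[C@@H](c2cc3cc(Br)ccc3nc2OC)c2cccc(OC)c2F)cc(OC)n1` gives 19 mL/min/kg
Compound 2 `CCOc1cc([C@](O)(CCN(C)C)[C@@H](c2cc3cc(Br)ccc3nc2OC)c2ccnc(OC)c2OC)cc(OC)n1` gives 9.5 mL/min/kg
Compound 3 `COc1cc([C@](O)(CCN(C)C)[C@@H](c2cc3cc(Br)ccc3nc2OC)c2ccnc(OC)c2OC)cc(OC2CCC2)n1` gives 11 mL/min/kg

Compound 2 at 9.5 mL/min/kg stands within the scatter of the other two compounds, so it cannot be separated from either of them on this assay alone. Compound 4 `CCOc1cc([C@](O)(CCN(C)C)[C@@H](c2cc3cc(Br)ccc3nc2OC)c2ccnc(OC)c2OC)cc(OC(C)C)n1` carries isopropyl in place of methyl on an oxygen on an aromatic ring. Among the compounds with values here, the closest precedent is compound 3, which also changes the group on an oxygen on an aromatic ring, though there cyclobutyl replaces ethyl (a 1.2-fold higher number from compound 2 to compound 3 (0.06 log units; within the scatter)). The change of aromatic group leading to compound 2 lies elsewhere in the molecule and also stayed within the scatter (a 2.0-fold lower number from compound 1 to compound 2 (0.30 log units; within the scatter)). Within the data shown here, neither measured step gives grounds for a real shift in either direction, and no measured compound carries this exact change. The expected result is a 1.1-fold higher number from compound 2 to compound 4 (0.02 log units; within the scatter) and thus no step beyond the scatter. For compound 4 the estimated clearance is 10 mL/min/kg with an expected range from 5.5 mL/min/kg to 18 mL/min/kg in this assay.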

Compound 4, clearance: 3.1 mL/min/kg
Estimate against measurement, compound 4: 3.2-fold (0.51 log units) above; the whole stated range lies above it.
By their numbers in this assay, from the lowest: compound 4; then compounds 2, 3 and 1 (each within the scatter of the next).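

In this assay, isopropyl in place of methyl on an oxygen on an aromatic ring gives a 3.1-fold lower number from compound 2 to compound 4 (0.49 log units; beyond the scatter), the only step among these compounds that lies beyond the scatter. The earlier change on such an oxygen, cyclobutyl in place of ethyl, gave a 1.2-fold higher number from compound 2 to compound 3 (0.06 log units; within the scatter) and so showed no real shift; this result shows that clearance can respond to the group on an oxygen on an aromatic ring, at least where compound 2 carries methyl. The data shown offer no measurement that accounts for this step.

On these data alone, it remains open whether a tert-butyl group or a longer chain such as n-propyl on this oxygen would give a similar number, which would help show whether branching matters. As far as these compounds go, it is also open whether the same methoxy to isopropoxy change would give a similar step with the 2-fluoro-3-methoxyphenyl group of compound 1.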